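Nitrofuran triazole amides: cytotoxicity on Vero cells

This account rests on a few compounds, and the source may have more. Where it says the series, first, only, none or still open, it means among the compounds named here.

Measured so far:
compound 1 `O=C(NCc1cn(Cc2ccc([N+](=O)[O-])cc2)nn1)c1ccc([N+](=O)[O-])o1`: 291000 nM
compound 2 `COc1ccc(Cn2cc(CNC(=O)c3ccc([N+](=O)[O-])o3)nn2)cc1[N+](=O)[O-]`: 176000 nM

In an ADME assay on Vero cells (Chlorocebus sabaeus) for cytotoxicity (a higher number here means a weaker inhibitor, a lower number a stronger inhibitor), compound 1 gives 291000 nM, and compound 2 gives 176000 nM; the two numbers sit within the scatter of each other, so compound 2 stands level with compound 1 on this assay. Compound 3 `O=C(NCc1cn(Cc2cccc([N+](=O)[O-])c2)nn1)c1ccc([N+](=O)[O-])o1` differs from compound 2 by hydrogen in place of methoxy on an aromatic carbon. Among the compounds with values here, no step between measured compounds covers this change, and the two numbers so far leave no room to expect one: the estimated step of a 1.3-fold higher number from compound 2 to compound 3 (0.10 log units; within the scatter) is none beyond the scatter. Compound 3 is expected to give 220000 nM, range 100000 nM to 450000 nM.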

Compound 3, half-maximal inhibitory concentration: 326000 nM
The estimate for compound 3 lay 1.5-fold (0.17 log units) below the measured number; low and high end bracket the measured number.
By their numbers in this assay, from the lowest: compounds 2, 1 and 3 (each within the scatter of the next).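

In this assay, hydrogen in place of methoxy on an aromatic carbon, ortho to a nitro group, gives a 1.9-fold higher number from compound 2 to compound 3 (0.27 log units; within the scatter), so the methoxy at this position shows no effect beyond the scatter. 3-Nitrophenyl in place of 4-nitrophenyl gives a 1.1-fold higher number from compound 1 to compound 3 (0.05 log units; within the scatter), so this change also stays within the scatter. Nothing available explains either step.

Open: whether an amine or a carboxylic acid on the same aromatic carbon would give a step beyond the scatter. As far as these compounds go, also open: whether a longer chain at the saturated chain carbon would do so.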